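Swapping a Chloromethyl for a Vinyl Group on Compound 1

This account rests on a few compounds, and the source may have more. Where it says the series, first, only, none or still open, it means among the compounds named here.

Of the compounds shown here, three have been tested in a functional assay on Rec1 cells (Homo sapiens) for inhibition, read by luminescence and CellTiter-Glo, with a stated time of 72 h; on this read-out higher numbers stand for weaker inhibition and lower numbers for stronger inhibition. Compound 1 `O=C(CCl)N1CCCC(n2nc(-c3ccc(Oc4ccccc4)cc3)cc2CO)C1` gives 400 nM, the lowest of the two numbers measured. Compound 3 `C=CC(=O)Nc1ccc(Cn2nc(-c3ccc(Oc4ccccc4)cc3)cc2CO)cc1` gives 3500 nM, which lies beyond the scatter above compound 1. For compound 2 `C=CC(=O)Nc1ccc(Cn2nc(-c3ccc(Oc4ccccc4)cc3)cc2C(=O)O)cc1` only a limit of the assay is reported, > 60000 nM, as noted in the limit of > 60000 nM in this assay, at which 1 of the 3 values shown sits. Within the data shown here, the one measured step, an at least 17-fold lower number from compound 2 to compound 3 (1.23 log units; beyond the scatter), concerns hydroxymethyl in place of carboxy and does not touch the part now to be changed. Compound 4 `C=CC(=O)N1CCCC(n2nc(-c3ccc(Oc4ccccc4)cc3)cc2CO)C1` differs from compound 1 as follows: vinyl in place of chloromethyl on a carbonyl carbon. Among the measured compounds shown here, no measured step bears on this change, so the step of a 1.5-fold higher number from compound 1 to compound 4 (0.18 log units; within the scatter) is expected to stay within the scatter. Compound 4 is therefore estimated at 600 nM, between 150 nM and 2500 nM.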

Compound 4, half-maximal inhibitory concentration: 5400 nM
For compound 4 the middle estimate is 9.0-fold (0.95 log units) below the measured one; measured number outside the range, above it.
By their numbers in this assay, from the lowest: compound 1; then compounds 3 and 4 (each within the scatter of the next). At a limit, above all of these: compound 2.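

Replacing chloromethyl with vinyl on the carbonyl carbon gives a 14-fold higher number from compound 1 to compound 4 (1.13 log units; beyond the scatter) in this assay. Among these compounds, this shows that the group on this carbonyl carbon strongly affects the read-out, which the earlier compounds could not show, since the one step among them lay elsewhere in the molecule. Nothing available here accounts for the size of this step.

From the compounds shown here alone, it remains open how other groups on this carbonyl carbon would behave, such as a bromomethyl group, a longer chain or a chain carrying an amine. Going by these compounds, whether chloromethyl would give a similar step on the core of compound 3 is also open.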